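Trifluoromethyl in Place of Fluoro: Expected Cytotoxicity of Compound 4

The compounds below may be only part of what the source reports. "The series", "measured", "known", "first", "only" and "open" are said of these compounds alone.

Measured compounds:
compound 1 `COc1cccc(/C=C/C(=O)Nc2cc(C(=O)c3cc(OC)c(OC)c(OC)c3)ccc2OC)c1`, in a functional assay on HeLa cells (Homo sapiens) for cytotoxicity, read by MTT assay, with a stated time of 72 h (a higher number here means a weaker inhibitor, a lower number a stronger inhibitor), compound 1 gives 3100 nM
compound 2 `C#CCOc1cccc(/C=C/C(=O)Nc2cc(C(=O)c3cc(OC)c(OC)c(OC)c3)ccc2OC)c1`, in this assay compound 2 gives 14000 nM
compound 3 `COc1ccc(C(=O)c2cc(OC)c(OC)c(OC)c2)cc1NC(=O)/C=C/c1ccc(F)cc1`, in this assay compound 3 gives 60 nM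

The three compounds share one core and differ only in the aryl group on the double-bonded chain carbon. Compound 3 stands lowest of the three numbers: the steps of a 52-fold lower number from compound 1 to compound 3 (1.71 log units; beyond the scatter) and a 230-fold lower number from compound 2 to compound 3 (2.37 log units; beyond the scatter) are both large. Compound 4 `COc1ccc(C(=O)c2cc(OC)c(OC)c(OC)c2)cc1NC(=O)/C=C/c1ccc(C(F)(F)F)cc1` differs from compound 3 by trifluoromethyl in place of fluoro on an aromatic carbon. For the measured compounds named here, no measured pair reproduces this change; the nearest guide is a 4.5-fold higher number from compound 1 to compound 2 (0.65 log units; beyond the scatter), where a group grown out from that same aryl ring raised the number modestly, while the large steps came from exchanging the whole aryl group. A modest rise in this assay is therefore expected, a 3.3-fold higher number from compound 3 to compound 4 (0.52 log units; beyond the scatter), though a step within the scatter cannot be excluded. For compound 4 the estimate in this assay is 200 nM, with a range from 40 nM to 1500 nM.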

Compound 4, half-maximal inhibitory concentration: 90 nM
Estimate against measurement, compound 4: 2.2-fold (0.35 log units) above; low and high end bracket the measured number.
By their numbers in this assay, from the lowest: compounds 3 and 4 (each within the scatter of the next); then compound 1; then compound 2.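

In this assay, trifluoromethyl in place of fluoro, on the aromatic carbon para to a large group, gives a 1.5-fold higher number from compound 3 to compound 4 (0.18 log units; within the scatter), so at this position the larger group reads the same as fluoro within the scatter. The large gaps to the other aryl groups also remain, at a 160-fold lower number from compound 2 to compound 4 (2.19 log units; beyond the scatter) and a 34-fold lower number from compound 1 to compound 4 (1.54 log units; beyond the scatter), which shows that a low number here is not confined to 4-fluorophenyl. Nothing available explains why fluoro and trifluoromethyl read alike at this position.

The compounds shown leave open how an amine, a carboxylic acid or a longer chain would read at this same position. Also open is how much of the large steps belongs to the group and how much to its place on the ring, as these two differ together among these compounds.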